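Swapping Iodo for Benzofuran on a Nucleoside Core

The compounds below may be only part of what the source reports. "The series", "measured", "known", "first", "only" and "open" are said of these compounds alone.

Compound 3 `COc1ncnc2c1c(I)cn2[C@@H]1O[C@H](CO)[C@@H](O)[C@H]1O` carries an iodo group, and in a functional assay on CEM-DNR-bulk cells (Homo sapiens), read by MTT assay, with a stated time of 72 h (a higher number here means a weaker inhibitor, a lower number a stronger inhibitor), compound 3 reaches only a limit of the assay rather than a number, at > 20000 nM. Its relative compound 1 `COc1ncnc2c1c(-c1ccsc1)cn2[C@@H]1O[C@H](CO)[C@@H](O)[C@H]1O` gives 7640 nM, and the measured step of an at least 2.6-fold higher number from compound 1 to compound 3 (0.41 log units; beyond the scatter) shows that iodo in place of thiophen-3-yl weakened inhibition. Compound 2 `Cc1ncnc2c1c(-c1cc3ccccc3o1)cn2[C@@H]1O[C@H](CO)[C@@H](O)[C@H]1O`, which already carries 1-benzofuran-2-yl on a differently substituted core, also sits at a limit, at > 20000 nM. Compound 4 `COc1ncnc2c1c(-c1cc3ccccc3o1)cn2[C@@H]1O[C@H](CO)[C@@H](O)[C@H]1O` is compound 3 changed by 1-benzofuran-2-yl in place of iodo on an aromatic carbon. The step from compound 1 to compound 3 suggests an aromatic group in place of iodo lowers the number, yet compound 2 shows benzofuran can still remain at the limit of > 20000 nM in this assay, at which 2 of the 3 values shown sit. The expected step is an at least 1.3-fold lower number from compound 3 to compound 4 (0.12 log units; that floor lies within the scatter). Compound 4 is therefore estimated at 15000 nM, with a range from 4000 nM to 50000 nM.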

Compound 4, half-maximal inhibitory concentration: 10800 nM
For compound 4 the middle estimate is 1.4-fold (0.14 log units) above the measured one; the range from low to high includes it.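

Benzofuran gives a measured value here where iodo gives only a limit: the step is an at least 1.8-fold lower number from compound 3 to compound 4 (0.26 log units; that floor lies within the scatter) and so its true size stays unknown. On the shared methoxy core, 1-benzofuran-2-yl and thiophen-3-yl read alike, with a 1.4-fold higher number from compound 1 to compound 4 (0.15 log units; within the scatter) so two different aromatic groups both give measured values at this position. Methoxy in place of methyl may also count, with an at least 1.8-fold lower number from compound 2 to compound 4 (0.26 log units; that floor lies within the scatter) but that step too starts from a limit: the limit of > 20000 nM in this assay, at which 2 of the 4 values shown sit.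

Going by these compounds, whether an amine, a carboxylic acid or a longer chain on this aromatic carbon would also give a measured value stays open.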